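The source may hold more compounds than are shown below. What is called first, only, known or untested is meant among the compounds shown, and "the series" means these compounds.

Measured in a functional assay on HeLa cells (Homo sapiens) for antiproliferative activity, read by MTT assay, with a stated time of 48 h; a higher number here means a weaker inhibitor of growth, a lower number a stronger inhibitor of growth:
- compound 1 `COC(=O)N1N=C(c2ccc(OC)cc2)CC1c1cc(OC)c(OC)c(OC)c1`: 2590 nM
- compound 2 `CCOC(=O)N1N=C(c2ccc(OC)cc2)CC1c1cc(OC)c(OC)c(OC)c1`: 8710 nM
- compound 3 `COc1ccc(C2=NN(C(=O)OCc3ccccc3)C(c3cc(OC)c(OC)c(OC)c3)C2)cc1`: > 10000 nM, a limit of the assay

Of the two true numbers, the lower belongs to compound 1 at 2590 nM. Compound 4 `COC(=O)N1N=C(c2ccc(O)cc2)CC1c1cc(OC)c(OC)c(OC)c1` departs from compound 1 in one place: hydrogen in place of methyl on an oxygen on an aromatic ring. This puts hydrogen in place of methyl on an oxygen on an aromatic ring, turning 4-methoxyphenyl into 4-hydroxyphenyl.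

For the measured compounds named here, no measured step touches that group. The two steps out of compound 1, a 3.4-fold higher number from compound 1 to compound 2 (0.53 log units; beyond the scatter) and an at least 3.8-fold higher number from compound 1 to compound 3 (0.58 log units; beyond the scatter), both fall on a saturated chain carbon bound to an oxygen next to a carbonyl group. Going by the values given here, they show only that a single change can move the number in this assay beyond the scatter, and they are a loose guide to size. A step no larger than these is therefore expected, leaning towards a higher number and possibly within the scatter. The expected step is a 1.5-fold higher number from compound 1 to compound 4 (0.19 log units; within the scatter). For compound 4 the estimated value is 4000 nM, with an expected range of 1200 nM to 13000 nM.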

Compound 4, concentration for 50% growth inhibition: 1140 nM
Estimate against measurement, compound 4: 3.5-fold (0.55 log units) above; measured number below the stated range.
By their numbers in this assay, from the lowest: compound 4; then compound 1; then compound 2. At a limit, above all of these: compound 3.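

In this assay, turning 4-methoxyphenyl into 4-hydroxyphenyl gives a 2.3-fold lower number from compound 1 to compound 4 (0.36 log units; beyond the scatter) and is the first single change shown that lowers the number rather than raising it. The earlier steps shown here all fell on a saturated chain carbon bound to an oxygen next to a carbonyl group, so they said nothing about the oxygen on the aromatic ring, where the methyl proves not to be needed for growth inhibition in these cells. Nothing measured here bears on why the number falls.

The compounds shown leave open whether an amine or a longer chain on that oxygen would lower the number further or raise it. They also leave open whether the same change would give a similar step on compound 2.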